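Swapping an Isopropyl Ether for an Isobutyl Ether

This account rests on a few compounds, and the source may have more. Where it says the series, first, only, none or still open, it means among the compounds named here.

Compound 1 `CC(C)Oc1ccc(-c2cc(C(=O)O)nn2-c2ccccc2)cc1` gives 7000 nM in an assay for displacement of a labelled ligand from Apoptosis regulator Bcl-2 (Homo sapiens), read by fluorescence polarization, with a stated time of 30 min; a lower number here means a stronger inhibitor, a higher number a weaker inhibitor.
Compound 2 `CC(C)COc1ccc(-c2cc(C(=O)O)nn2-c2ccccc2)cc1` reaches only the limit of > 10000 nM in this assay, so no number is known for it.
Compound 3 `CCOc1ccc(-c2c(NC(=O)c3ccc(OC(C)C)cc3)c(C(=O)O)nn2-c2ccc(Oc3ccccc3)cc2)cc1` gives 28 nM in this assay.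

Compound 1 and compound 2 share a small core and differ in one group: isobutyl in place of isopropyl on an oxygen on an aromatic ring. That change made an at least 1.4-fold higher number from compound 1 to compound 2 (0.15 log units; that floor lies within the scatter), and the floor on that step comes from the limit of > 10000 nM in this assay, at which 1 of the 3 values shown sits. Compound 3 is a much larger molecule; the difference between its core and that of compound 1 is not broken down here. Against compound 1 it shows a far lower number in this assay, beyond the scatter.

Compound 4 `CCOc1ccc(-c2c(NC(=O)c3ccc(OCC(C)C)cc3)c(C(=O)O)nn2-c2ccc(Oc3ccccc3)cc2)cc1` is not yet measured. It differs from compound 3 by isobutyl in place of isopropyl on an oxygen on an aromatic ring, the same change as that from compound 1 to compound 2, made on the same kind of place. Because compound 1 to compound 2 showed an at least 1.4-fold higher number from compound 1 to compound 2 (0.15 log units; that floor lies within the scatter), a modest weakening is expected for compound 4, namely a 2.1-fold higher number from compound 3 to compound 4 (0.33 log units; beyond the scatter). Compound 4 is therefore estimated at 60 nM, most likely between 25 nM and 200 nM.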

Compound 4, inhibition constant: 1040 nM
The estimate for compound 4 lay 17-fold (1.24 log units) below the measured number, outside the stated range (above it).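

On the core of compound 3, isobutyl in place of isopropyl on an oxygen on an aromatic ring has a large effect in this assay, giving a 37-fold higher number from compound 3 to compound 4 (1.57 log units; beyond the scatter). Set beside the smaller core of compound 1, this shows that the weak signal seen there gave little guide to the size of the step on the bigger core, but it does not show that the change truly behaves differently on the two cores: the same change on two cores in this assay, an at least 1.4-fold higher number (0.15 log units; that floor lies within the scatter) from compound 1 to compound 2 and a 37-fold higher number (1.57 log units; beyond the scatter) from compound 3 to compound 4; the limit leaves it open whether they differ. From the compounds shown here alone, compound 2 stands at a limit of the assay and not at a number, so the real size of the first step stays unknown: the limit of > 10000 nM in this assay, at which 1 of the 4 values shown sits.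

The compounds shown leave open whether a smaller group on that oxygen, such as methyl, or a straight butyl chain would keep the number of compound 3 or lose it as isobutyl does. They also leave open how an ether carrying an amine or a hydroxyl group on its chain would fare on this core.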